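Aryl swap on the triazole nitrogen: compound 3 to compound 4

The compounds below may be only part of what the source reports. "The series", "measured", "known", "first", "only" and "open" are said of these compounds alone.

Measured so far in a functional assay on the whole organism (strain Swiss albino) for inhibition, with Mus musculus as the target, with a stated time of 0.5 h; a lower number here means that less compound is needed, a higher number that more compound is needed for the effect:
compound 1 `Cc1ccccc1-n1c(Nc2nc(-c3ccc(Br)cc3)cs2)n[nH]c1=S` gives 30 mg/kg
compound 2 `COc1ccccc1-n1c(Nc2nc(-c3ccc(Cl)cc3)cs2)n[nH]c1=S` gives 100 mg/kg
compound 3 `Cc1ccc(-n2c(Nc3nc(-c4ccc(Cl)cc4)cs3)n[nH]c2=S)cc1` gives 300 mg/kg

Compound 3 stands highest of the three numbers: its nearest neighbour is compound 2, and compound 1 lies furthest from it. Among the compounds with values here, the single one-place step in hand, a 3.0-fold higher number from compound 2 to compound 3 (0.48 log units; beyond the scatter), shows that moving from 2-methoxyphenyl to 4-methylphenyl on the aromatic nitrogen raised the number beyond the scatter.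

Compound 4 `Cc1ccccc1-n1c(Nc2nc(-c3ccc(Cl)cc3)cs2)n[nH]c1=S` is the next compound, differing from compound 3 by 2-methylphenyl in place of 4-methylphenyl on an aromatic nitrogen. Within the data shown here, the step bears on the same aromatic nitrogen as the one from compound 2 to compound 3, and it reverses the move toward 4-methylphenyl. Compound 1, which also carries 2-methylphenyl on that nitrogen, gives 30 mg/kg in this assay, the lowest number in the set. A lower number for compound 4 than for compound 3 is therefore expected, estimated as a 6.0-fold lower number from compound 3 to compound 4 (0.78 log units; beyond the scatter). Compound 4 is expected to give about 50 mg/kg, within 20 mg/kg to 150 mg/kg.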

Compound 4, minimum effective dose: 100 mg/kg
Beside the measured number, compound 4's estimate is 2.0-fold (0.30 log units) below it, and the stated range covers the measured number.
By their numbers in this assay, from the lowest: compound 1; then compounds 2 and 4 (each within the scatter of the next); then compound 3.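

In this assay the same methyl group, moved on the aryl ring with the rest of the structure unchanged, gives a 3.0-fold lower number from compound 3 to compound 4 (0.48 log units; beyond the scatter) and so shows that 2-methylphenyl and 4-methylphenyl on the aromatic nitrogen are not equivalent in this pair. Methyl in place of methoxy on an aromatic carbon gives no change at the digits printed from compound 2 to compound 4 (within the scatter) while chloro in place of bromo gives a 3.3-fold higher number from compound 1 to compound 4 (0.52 log units; beyond the scatter) and thus shows that the halogen, a second point of the structure, also moves the number beyond the scatter. No measurement in hand accounts for either step.

On these data alone, whether an unsubstituted phenyl, or an amine or a carboxylic acid on that aryl ring, would fit this picture remains open. Also open, as far as these compounds go, is whether the halogen step holds with 4-methylphenyl on the nitrogen.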